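The source may report more compounds than this note shows. Statements on the series, on what has been measured and on what is new or still open speak of the compounds shown alone.

Measured compounds:
compound 1 `COc1cc(Br)cc(/C=C/C(=O)c2ccccc2)c1O`, a functional assay on MCF7 cells (Homo sapiens) for antiproliferative activity, read by sulforhodamine B assay, with a stated time of 72 h, tested at 10 uM (on this read-out higher numbers stand for a weaker effect at the one concentration tested and lower numbers for a stronger effect), 67%
compound 2 `COc1cccc(C(=O)/C=C/c2cc(Br)cc(OC)c2O)c1`, this assay 77.3%
compound 3 `COC(=O)C1=C(N)Oc2c(OC)cc(Br)cc2C1CC(=O)c1ccc(Br)cc1`, this assay 50.2%

Compound 3 stands lowest of the three; the difference between its core and that of compound 2 is not broken down here. Within the open-chain pair, the change hydrogen in place of methoxy on an aromatic carbon gives a number 10.3 percentage points lower from compound 2 to compound 1 (beyond the scatter). Compound 4 `COC(=O)C1=C(N)Oc2ccc(Br)cc2C1CC(=O)c1ccc(Br)cc1`, not yet measured, is made from compound 3 by hydrogen in place of methoxy on an aromatic carbon; the place differs, here on a ring that is part of a fused system, ortho to a fused ring and meta to a bromo group, so this is the same kind of change, not the same. Among the compounds with values here, for compound 4 a step of about a number 8.2 percentage points lower from compound 3 to compound 4 (within the scatter) is expected, resting on the single comparable step a number 10.3 percentage points lower from compound 2 to compound 1 (beyond the scatter) and on what compound 3 gives, 50.2%. Compound 4 is therefore estimated at 42%, between 28% and 58%.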

Compound 4, a percentage reported as activity, at one concentration (the size of the read-out at that concentration, not a potency): 72.5%
Compound 4: the middle estimate sits 30.5 percentage points below what was measured, outside the stated range (above it).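

In this assay, hydrogen in place of methoxy gives a number 22.3 percentage points higher from compound 3 to compound 4 (beyond the scatter), a weaker effect at the one concentration tested. The same change does not give the same result on the two cores: the same change on two cores in this assay, a number 10.3 percentage points lower (beyond the scatter) from compound 2 to compound 1 and a number 22.3 percentage points higher (beyond the scatter) from compound 3 to compound 4, 32.6 percentage points apart, beyond the scatter of two such steps A step read on one core is therefore no guide to the other in this series, but two pairs, with the change at different places, do not show whether the core or the place sets the direction, and they give no potency.

The compounds shown leave open how an amine, a hydroxyl or a longer alkoxy chain at this place on the core of compound 3 would read. They also leave open whether replacing the bromo group on that ring would alter the step.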